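A few compounds are considered here, and "the series" means these few. Any claim that something is new, unique, unknown or untested is made for them only; others in the source may bear on it.

Compound 1 `Cc1nc(C)c(/C=C/C(=O)/C=C/c2ccc(O)cc2)nc1C`: 4790 nM
Compound 2 `COc1cc(/C=C/C(=O)/C=C/c2nc(C)c(C)nc2C)ccc1O`: 600 nM

For the measured compounds named here, in a functional assay on A549/CDDP cells (Homo sapiens) for antiproliferative activity, read by MTT assay, with a stated time of 72 h (a lower number here means a stronger inhibitor, a higher number a weaker inhibitor), compound 2 gives 600 nM, the lower of the two numbers measured so far. Compound 3 `COc1ccc(/C=C/C(=O)/C=C/c2nc(C)c(C)nc2C)cc1OC`, not yet measured, differs from compound 2 in one place: methyl in place of hydrogen on an oxygen on an aromatic ring. This is methyl in place of hydrogen on an oxygen on an aromatic ring, so hydroxy becomes methoxy. Going by the values given here, only one measured step bears on it, an 8.0-fold lower number from compound 1 to compound 2 (0.90 log units; beyond the scatter), which brought in a methoxy in place of hydrogen on an aromatic carbon. Among the compounds with values here, that is a different change, so it offers only loose guidance, and no measured step shows a change on that oxygen. A step beyond the scatter is therefore not expected, with a slightly higher number the likelier direction. The expected step is a 1.5-fold higher number from compound 2 to compound 3 (0.18 log units; within the scatter). For compound 3 the estimated value is 900 nM, with an expected range from 250 nM to 3500 nM.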

Compound 3, half-maximal inhibitory concentration: 2440 nM
Compound 3: the middle estimate sits 2.7-fold (0.43 log units) below what was measured; low and high end bracket the measured number.
By their numbers in this assay, from the lowest: compound 2; then compounds 3 and 1 (each within the scatter of the next).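

Replacing the hydrogen on this oxygen with a methyl turns the hydroxy into a methoxy and gives a 4.1-fold higher number from compound 2 to compound 3 (0.61 log units; beyond the scatter) in this assay. For the compounds shown here, this is the first measured change on this oxygen, and it shows that the position responds to substitution: the step is modest but lies beyond the scatter, so the hydroxy of compound 2 cannot be swapped for a methoxy without a loss of potency here. Nothing available explains this loss, so the result records what happens but not why.

Going by these compounds, it remains open whether an ethyl or longer chain on this oxygen, or an amine or a carboxylic acid in place of the hydroxy, would give a lower or higher number. On these data alone, it is also open whether the same methyl on the hydroxy of compound 1 would produce a similar step.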